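This account rests on a few compounds, and the source may have more. Where it says the series, first, only, none or still open, it means among the compounds named here.

Among the compounds with values here, compound 1 `CC(=O)c1ccc(O[C@@H]2O[C@H](COC(=O)c3cccnc3)[C@@H](O)[C@H](O)[C@H]2O)cc1` is the first member; in an ADME assay on HepG2 2.2.15 cells (Homo sapiens) for cytotoxicity, read by MTT assay (on this read-out higher numbers stand for lower toxicity in this test and lower numbers for higher toxicity in this test), compound 1 gives > 1650000 nM, which is a limit of the measurement and not a number. Compound 2 `CC(=O)c1ccc(O[C@@H]2O[C@H](COC(=O)c3cccs3)[C@@H](O)[C@H](O)[C@H]2O)cc1` gives 1570000 nM in this assay. The step of an at least 1.0-fold lower number from compound 1 to compound 2 (0.02 log units; that floor lies within the scatter) cannot be sized beyond a floor, since one of its ends sits at the limit of > 1650000 nM in this assay, at which 1 of the 2 values shown sits. Within the data shown here, compound 2 thus holds the only actual number in this assay; the one other value shown is a limit. Compound 3 `CC(=O)c1ccc(O[C@@H]2O[C@H](CO[C@@H]3OC[C@@H](O)[C@H](O)[C@H]3O)[C@@H](O)[C@H](O)[C@H]2O)cc1` differs from compound 2 in that (3,4,5-trihydroxyoxan-2-yl in place of (thiophen-2-yl)carbonyl on an oxygen on a saturated carbon). Among the measured compounds shown here, the single measured step exchanges one aromatic ring for another on the carbonyl carbon and stays within the scatter; no measured step exchanges the whole (thiophen-2-yl)carbonyl for a 3,4,5-trihydroxyoxan-2-yl, so nothing measured speaks directly to this change. Both measured values sit close to the top of what this assay resolves, so for compound 3 the expected step is a 1.1-fold higher number from compound 2 to compound 3 (0.03 log units; within the scatter), with a fair chance that only a limit is returned. Compound 3 is expected to give 1700000 nM, in the range 800000 nM to 3500000 nM.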

Compound 3, half-maximal cytotoxic concentration: > 2590000 nM
Compound 3: no number, only a limit; the forecaster's own chance of this, stated with the estimate: 60%; middle value at least 1.5-fold (0.18 log units) from the limit.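

On an oxygen on a saturated carbon, 3,4,5-trihydroxyoxan-2-yl in place of (thiophen-2-yl)carbonyl gives an at least 1.6-fold higher number from compound 2 to compound 3 (0.21 log units; that floor lies within the scatter) in this assay, so this change is not shown to exceed the scatter. Compound 3 gives > 2590000 nM, a limit and not a number, and the size of the step stays open because of it: the limit of > 2590000 nM in this assay, at which 1 of the 3 values shown sits.

The earlier compounds shown here showed only aromatic rings on a carbonyl carbon at this place; compound 3 shows that a six-membered non-aromatic ring without that carbonyl also returns a limit in this test, as compound 1 did. The step between those two compounds cannot be read.

From the compounds shown here alone, what an amine, a carboxylic acid or a longer alkyl chain would do on this oxygen stays open, as does whether any replacement here moves the number beyond the scatter. It also stays open whether (thiophen-2-yl)carbonyl, (pyridin-3-yl)carbonyl and 3,4,5-trihydroxyoxan-2-yl differ at all in this test, and the compounds shown give no actual number for any group but the first of these.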